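A few compounds are considered here, and "the series" means these few. Any claim that something is new, unique, unknown or untested is made for them only; others in the source may bear on it.

Measured in a physicochemical assay for solubility, in phosphate buffer, at pH 6.8; on this read-out higher numbers stand for higher solubility and lower numbers for lower solubility:
- compound 1 `COc1ccccc1C1C(C(=O)C(C)(C)C)=C(O)C(=O)N1c1ccc(-c2ccsc2)cc1`: 900 nM
- compound 2 `C[S+]([O-])CCOc1ccccc1C1C(C(=O)C(C)(C)C)=C(O)C(=O)N1c1ccc(-c2ccsc2)cc1`: > 50000 nM

The entry for compound 2 is a limit of the assay and not a number: it stands at the limit of > 50000 nM in this assay, at which 1 of the 2 values shown sits.

Compound 3 `CN(C)C(=O)COc1ccccc1C1C(C(=O)C(C)(C)C)=C(O)C(=O)N1c1ccc(-c2ccsc2)cc1` has not been measured. It keeps the shared core and differs from compound 2 in one place: a group of 5 heavy atoms (3 carbon, 1 nitrogen, 1 oxygen; no ring) in place of a group of 4 heavy atoms (2 carbon, 1 oxygen, 1 sulfur; no ring), on a saturated chain carbon bound to an oxygen on an aromatic ring.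

Within the data shown here, one measured step bears on this, and it is large: an at least 55-fold higher number from compound 1 to compound 2 (1.74 log units; beyond the scatter). That step filled the same place, so compound 3 is expected to stay well clear of compound 1 in this assay. Among the measured compounds shown here, no measured step compares the two groups directly, and the true number for compound 2 is unknown, so the expectation is loose.

A modest move toward lower numbers is expected, estimated as an at least 2.5-fold lower number from compound 2 to compound 3 (0.39 log units; beyond the scatter).

For compound 3, the estimated value is 20000 nM, with an expected range from 5000 nM to 50000 nM.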

Compound 3, solubility: > 50000 nM
Compound 3 gave a limit, no number; the forecaster's own chance of this, stated with the estimate: 25%; middle value at least 2.5-fold (0.39 log units) away from the limit.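

In this assay, the saturated chain carbon bound to an oxygen on an aromatic ring now carries a second group with a large result, as dimethylcarbamoyl in place of hydrogen gives an at least 55-fold higher number from compound 1 to compound 3 (1.74 log units; beyond the scatter). The large rise seen with compound 2 is therefore not tied to its sulfur-bearing group, since the dimethylcarbamoyl of compound 3 holds no sulfur and brings a nitrogen instead. The step between compound 2 and compound 3 cannot be read, because both entries are limits and not numbers: the limit of > 50000 nM in this assay, at which 2 of the 3 values shown sit.

Which of these two groups gives the higher number stays open, as does how far past the limit either compound lies. Whether an amine, a carboxylic acid or a longer chain at this place would also stay well clear of compound 1 cannot be told from the compounds shown.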